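The source may report more compounds than this note shows. Statements on the series, on what has been measured and on what is new or still open speak of the compounds shown alone.

In a functional assay on Raji cells (Homo sapiens) for cytotoxicity, with a stated time of 72 h (a lower number here means that less compound is needed, a higher number that more compound is needed for the effect), compound 1 `C=C[C@](C)(CCCC(C)C)CCc1ccc(O)cc1` gives > 26000 nM, a limit and not a number. Compound 2 `C=C[C@@](C)(/C=C/c1ccc(O)cc1)CC/C=C(C)/C=C/C(=O)OCC` gives > 26000 nM, also a limit. Compound 3 `C=C[C@@](C)(/C=C/c1ccc(O)c(C=O)c1)CCC=C(C)C` gives > 26000 nM, again a limit, and this is where it stands. All three share this ceiling: the limit of > 26000 nM in this assay, at which 3 of the 3 values shown sit.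

Compound 4 `C=C[C@@](C)(/C=C/c1ccc(O)c(/C=C(\C)C(=O)OCC)c1)CCC=C(C)C` has 2-(ethoxycarbonyl)prop-1-en-1-yl in place of formyl on an aromatic carbon, ortho to a hydroxy group: 2-(ethoxycarbonyl)prop-1-en-1-yl in place of formyl on an aromatic carbon. Among the measured compounds shown here, no step between measured compounds shows what this swap does, so the expectation rests only on the limit of compound 3, > 26000 nM. The expected step, an at least 1.3-fold lower number from compound 3 to compound 4 (0.11 log units; that floor lies within the scatter), is small and points, if anywhere, toward a lower number. Compound 4 is estimated at 20000 nM, with an expected range from 9000 nM to 45000 nM.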

Compound 4, half-maximal effective concentration: > 26000 nM
Compound 4 was reported as a limit; the forecaster's own chance of this, stated with the estimate: 60%; middle value at least 1.3-fold (0.11 log units) away from the limit.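

Compound 3 and compound 4 both sit at a limit rather than a number, so no step between them can be read: the limit of > 26000 nM in this assay, at which 4 of the 4 values shown sit.

On these data alone, what swapping formyl for 2-(ethoxycarbonyl)prop-1-en-1-yl does in this assay stays open.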